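The source may report more compounds than this note shows. Statements on the series, on what has been measured and on what is new or still open speak of the compounds shown alone.

Of the compounds shown here, three have so far been measured in an ADME assay on microsomes from liver (Homo sapiens) for metabolic stability, with a stated time of 10 min; on this read-out lower numbers stand for a less stable compound and higher numbers for a more stable compound. Compound 3 `CC(C)OC(=O)NCCS(=O)(=O)NC(=O)c1ccc(Nc2nc(NC3(c4ccc(Cl)cc4)CC3)nc(OCC(F)(F)F)n2)cc1` stands highest of the three, giving 100%. Its nearest neighbour is compound 1 `CC(C)NCCS(=O)(=O)NC(=O)c1ccc(Nc2nc(NC3(c4ccc(Cl)cc4)CC3)nc(OCC(F)(F)F)n2)cc1`, which in this assay gives 89%. Furthest away lies compound 2 `CCCCCNc1nc(Nc2ccc([N+](=O)[O-])cc2)nc(OCC(F)(F)F)n1`, a compound of a different build; in this assay compound 2 gives 74%. Going by the values given here, only one pair of measured compounds differs in a single place, and that step reads a number 11 percentage points higher from compound 1 to compound 3 (beyond the scatter), a modest rise that lies beyond the scatter.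

Compound 4 `CS(=O)(=O)NC(=O)c1ccc(Nc2nc(NC3(c4ccc(Cl)cc4)CC3)nc(OCC(F)(F)F)n2)cc1` has not yet been measured. It differs from compound 3 in one place: hydrogen in place of ((isopropoxycarbonyl)amino)methyl on a saturated chain carbon bound to a sulfonyl sulfur. The whole arm that carries the carbamate is thus cut away, and only a methylsulfonyl group remains.

The step from compound 1 to compound 3 bears on this change, since it altered the end of the very arm that now disappears. Because that step gave a number 11 percentage points higher from compound 1 to compound 3 (beyond the scatter), taking the arm away altogether is expected to cost some of that gain, so a modest fall in this assay is expected, a number 15 percentage points lower from compound 3 to compound 4 (beyond the scatter). Compound 4 is therefore estimated at 85%, within a range from 65% to 100%.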

Compound 4, percent of the compound remaining: 100%
Beside the measured number, compound 4's estimate is 15 percentage points below it; low and high end bracket the measured number.
By their numbers in this assay, from the lowest: compound 2; then compound 1; then compounds 3 and 4 (each within the scatter of the next).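

In this assay, methyl takes the place of the 2-((isopropoxycarbonyl)amino)ethyl arm on the sulfonyl, and this gives no change at the digits printed from compound 3 to compound 4 (within the scatter). A compound with only a methylsulfonyl group at this position matches the compound carrying the full arm. Set against compound 1, the same position now gives two comparisons. The change to hydrogen in place of (isopropylamino)methyl gives a number 11 percentage points higher from compound 1 to compound 4 (beyond the scatter), a step as large as the one seen earlier on swapping the isopropyl for isopropoxycarbonyl on the arm's nitrogen. Among these three compounds only the one ending in the isopropylamine sits lower. Nothing measured here explains why that arm gives the lower number in this series.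

On these data alone, what remains open is how a simple ethyl or a longer alkyl chain on the sulfonyl would read, with no nitrogen in it at all. It is equally unclear whether a primary amine or a carboxylic acid at the end of the arm would fall with compound 1 or with compound 3 and compound 4.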